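Changing the Amide Aryl Group: Compound 2 to Compound 4

The source may hold more compounds than are shown below. What is called first, only, known or untested is meant among the compounds shown, and "the series" means these compounds.

Compound 1 `CCN(CC)CCNc1cc(C)c2cc(NC(=O)c3ccc(Cl)c(Cl)c3)ccc2n1` gives 3710 nM in a functional assay on SK-BR-3 cells (Homo sapiens) for antiproliferative activity, read by MTT assay, with a stated time of 72 h; on this read-out lower numbers stand for stronger inhibition and higher numbers for weaker inhibition.
Compound 2 `CCc1ccccc1C(=O)Nc1ccc2nc(N3CCN(CC)CC3)cc(C)c2c1` gives 23900 nM.
Compound 3 `Cc1cc(N2CCCC2)nc2ccc(NC(=O)c3ccc(Cl)c(Cl)c3)cc12` gives 43400 nM.

Compound 2 stands second highest of the three numbers: compound 3 lies within the scatter of it, while compound 1 lies a good deal lower, beyond the scatter. Compound 4 `CCN1CCN(c2cc(C)c3cc(NC(=O)c4ccc(Br)cc4)ccc3n2)CC1` differs from compound 2 in one place: 4-bromophenyl in place of 2-ethylphenyl on a carbonyl carbon. Within the data shown here, the only measured step, a 12-fold higher number from compound 1 to compound 3 (1.07 log units; beyond the scatter), concerns the amine attached to the shared core, not the amide aryl group, so no measured step bears directly on this change. Compounds 1 and 3 share the same amide aryl group yet differ widely, so that group alone does not settle the number. No step beyond the scatter is therefore expected. Compound 4 is expected to give about 15000 nM, between 5000 nM and 45000 nM, an expected step of a 1.6-fold lower number from compound 2 to compound 4 (0.20 log units; within the scatter).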

Compound 4, half-maximal inhibitory concentration: 6310 nM
For compound 4 the middle estimate is 2.4-fold (0.38 log units) above the measured one; the measured number falls inside the stated range.
By their numbers in this assay, from the lowest: compounds 1 and 4 (each within the scatter of the next); then compounds 2 and 3 (each within the scatter of the next).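

In this assay, the amide aryl group proves able to move the number on its own: 4-bromophenyl in place of 2-ethylphenyl on a carbonyl carbon gives a 3.8-fold lower number from compound 2 to compound 4 (0.58 log units; beyond the scatter) with the amine on the shared core left unchanged. Among these compounds, the only earlier step changed that amine instead, so this is the first measured sign that the carbonyl substituent matters too. No measurement available here explains the step.

Both the substituent and its ring position change in this swap, so the two effects cannot be separated. Placing 4-ethylphenyl or 2-bromophenyl on the same carbonyl carbon would pull them apart, and how either group would read remains open.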